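Adding a methyl to the phenyl of compound 2

The compounds below may be only part of what the source reports. "The series", "measured", "known", "first", "only" and "open" are said of these compounds alone.

In a functional assay on HL-60 cells (Homo sapiens) for cytotoxicity, read by MTT assay, with a stated time of 72 h (on this read-out lower numbers stand for stronger inhibition and higher numbers for weaker inhibition), compound 1 (`Cc1ccc(S(=O)(=O)c2nc3ccccc3nc2N2CCc3ccccc3C2)cc1`) gives 3610 nM and compound 2 (`O=S(=O)(c1ccccc1)c1nc2ccccc2nc1N1CCC(O)CC1`) gives 2900 nM. Among the compounds with values here, these are the only two numbers available, and they lie within the scatter of each other, so compound 2 stands level with compound 1. Compound 3 (`Cc1ccc(S(=O)(=O)c2nc3ccccc3nc2N2CCC(O)CC2)cc1`) differs from compound 2 by methyl in place of hydrogen on an aromatic carbon, phenyl becoming 4-methylphenyl: methyl in place of hydrogen on an aromatic carbon. Within the data shown here, no pair of measured compounds isolates this change, so there is no direct measure of its size. Compound 1 also bears the 4-methylphenyl group and gives 3610 nM, which offers a weak hint that the group is tolerated. No change beyond the scatter is expected in this assay, and the estimated move is a 1.0-fold higher number from compound 2 to compound 3 (0.01 log units; within the scatter). Compound 3 is expected at 3000 nM, with an estimated range of 1300 nM to 6500 nM.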

Compound 3, half-maximal inhibitory concentration: 4050 nM
For compound 3 the middle estimate is 1.4-fold (0.13 log units) below the measured one, within the range that was stated.
By their numbers in this assay, from the lowest: compounds 2, 1 and 3 (each within the scatter of the next).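

In this assay the methyl on the aromatic carbon para to a large group now has a direct measure, a 1.4-fold higher number from compound 2 to compound 3 (0.15 log units; within the scatter) and so, with the 4-hydroxypiperidin-1-yl group in place, phenyl and 4-methylphenyl cannot be told apart here. With 4-methylphenyl held constant, the other position gives a 1.1-fold higher number from compound 1 to compound 3 (0.05 log units; within the scatter) and so the exchange of 1,2,3,4-tetrahydroisoquinolin-2-yl for 4-hydroxypiperidin-1-yl also leaves the two compounds level in this read-out. No measurement is at hand that bears on either result.

On these data alone, whether a chlorine, a methoxy group or a carboxylic acid in place of this methyl would move the number beyond the scatter remains open. So does the effect of a primary amine or a morpholine in place of 4-hydroxypiperidin-1-yl.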